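The source may hold more compounds than are shown below. What is called first, only, known or untested is meant among the compounds shown, and "the series" means these compounds.

Compound 1 `ClCc1ccc(Cn2cnc3c(Cl)ncnc32)cc1` stands lowest of the two numbers measured in a functional assay on SF-268 cells (Homo sapiens) for cytotoxicity, read by sulforhodamine B assay, with a stated time of 48 h; a lower number here means a stronger inhibitor of growth, a higher number a weaker inhibitor of growth: compound 1 gives 640 nM, while compound 2 `ClCc1cccc(Cn2cnc3c(Cl)nc(Cl)nc32)c1` gives 2510 nM, a gap beyond the usual scatter. Compound 3 `ClCc1ccc(Cn2cnc3c(Cl)nc(Cl)nc32)cc1`, not yet measured, is built from compound 1 by chloro in place of hydrogen on an aromatic carbon. Compound 2 carries that same second chloro group, but its chloromethyl-bearing ring is joined to the core differently, so its weaker number cannot be read as the effect of the chloro alone. A modest weakening is expected, a 1.7-fold higher number from compound 1 to compound 3 (0.24 log units; within the scatter), possibly within the scatter. Compound 3 is estimated at 1100 nM, within 400 nM to 3000 nM.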

Compound 3, concentration for 50% growth inhibition: 2510 nM
Beside the measured number, compound 3's estimate is 2.3-fold (0.36 log units) below it; low and high end bracket the measured number.
By their numbers in this assay, from the lowest: compound 1; then compounds 2 and 3 (each within the scatter of the next).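

Chloro in place of hydrogen on an aromatic carbon, between two ring nitrogen atoms, gives a 3.9-fold higher number from compound 1 to compound 3 (0.59 log units; beyond the scatter) in this assay, so this position does not take the added chloro without a loss of growth inhibition. With the chloromethyl-bearing ring joined differently but this chloro present in both, compound 3 gives 2510 nM and compound 2 gives 2510 nM as well. From the compounds shown here alone, whether an amine or a methoxy group at this position would fare better stays open. Nothing measured here says why the number rises.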